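The source may report more compounds than this note shows. Statements on the series, on what has been measured and on what is new or still open speak of the compounds shown alone.

Measured compounds:
compound 1 `CC(C(=O)NCc1ccc(C(F)(F)F)nc1N1CCCC1)c1ccc(NS(C)(=O)=O)c(F)c1`, in a functional assay on CHO-K1 cells for antagonist activity at transient receptor potential cation channel subfamily V member 1 (Homo sapiens), read by FLIPR; a lower number here means a stronger inhibitor, a higher number a weaker inhibitor: 0.6 nM
compound 2 `CC(C(=O)NCc1ccc(C(F)(F)F)nc1N1CCC(CN(C)C)CC1)c1ccc(NS(C)(=O)=O)c(F)c1`, in this assay: 2.1 nM

Among the compounds with values here, compound 2 holds the highest of the two numbers; the only measured step, a 3.5-fold higher number from compound 1 to compound 2 (0.54 log units; beyond the scatter), lies beyond the scatter. Compound 3 `CC(C(=O)NCc1ccc(C(F)(F)F)nc1N1CCCCCC1)c1ccc(NS(C)(=O)=O)c(F)c1` differs from compound 2 in one place: azepan-1-yl in place of 4-((dimethylamino)methyl)piperidin-1-yl on an aromatic carbon. Within the data shown here, only that one step bears on this change, and it was modest, so for compound 3 a modest step in the opposite direction is expected, as a 2.1-fold lower number from compound 2 to compound 3 (0.32 log units; beyond the scatter). Compound 3 is therefore estimated at 1 nM in this assay, with a range from 0.3 nM to 3 nM.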

Compound 3, inhibition constant: 0.8 nM
The estimate for compound 3 lay 1.3-fold (0.10 log units) above the measured number; the range from low to high includes it.
By their numbers in this assay, from the lowest: compounds 1 and 3 (each within the scatter of the next); then compound 2.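

At this position, next to the ring nitrogen, azepan-1-yl in place of pyrrolidin-1-yl gives a 1.3-fold higher number from compound 1 to compound 3 (0.12 log units; within the scatter), so in this assay these two rings cannot be told apart. Azepan-1-yl in place of 4-((dimethylamino)methyl)piperidin-1-yl gives a 2.6-fold lower number from compound 2 to compound 3 (0.42 log units; beyond the scatter), which leaves compound 2 alone with the higher number among the three compounds. No data shown here offer a reason for this difference.

The compounds shown do not separate the piperidine ring from its dimethylaminomethyl side chain. Unsubstituted piperidin-1-yl would address this, and morpholin-4-yl would test a ring oxygen at this position.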